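This account rests on a few compounds, and the source may have more. Where it says the series, first, only, none or still open, it means among the compounds named here.

Measured in a functional assay on MT4 cells (Homo sapiens) for cytotoxicity, read by MTT assay; on this read-out higher numbers stand for lower toxicity in this test and lower numbers for higher toxicity in this test:
- compound 1 `Cc1c(O)nc(SCc2ccc(O)cc2)nc1Cc1c(Cl)cccc1Cl`: 41000 nM
- compound 2 `Cc1c(O)nc(SCc2ccc(C#N)cc2)nc1Cc1c(F)cccc1F`: > 65000 nM
- compound 3 `COc1ccc(CCCSc2nc(O)c(C)c(Cc3c(Cl)cccc3Cl)n2)cc1`: 1000 nM

The entry for compound 2, > 65000 nM, is a limit of this assay and not a number. Of the two true numbers, compound 1 holds the higher, and compound 3 lies lower by more than the scatter. Compound 4 `Cc1c(O)nc(SCc2cccc(F)c2)nc1Cc1c(Cl)cccc1Cl` has 3-fluorophenyl in place of 4-hydroxyphenyl on a saturated chain carbon bound to a sulfur. For the measured compounds named here, no measured pair isolates this change, so the expectation rests on compound 1 at 41000 nM, with no shift beyond the scatter foreseen in either direction. The expected step is a 1.0-fold lower number from compound 1 to compound 4 (0.01 log units; within the scatter). For compound 4 the estimated value is 40000 nM, with an expected range of 13000 nM to 100000 nM.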

Compound 4, half-maximal cytotoxic concentration: > 61000 nM
Compound 4: only a limit was reported; the forecaster's own chance of this, stated with the estimate: 35%; at least 1.5-fold (0.18 log units) between middle value and limit.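

In this assay compound 4 gives > 61000 nM, which is a limit of the assay and not a number. On a saturated chain carbon bound to a sulfur, 3-fluorophenyl, which carries no hydrogen-bond donor or acceptor, replaces 4-hydroxyphenyl with an at least 1.4-fold higher number from compound 1 to compound 4 (0.17 log units; that floor lies within the scatter), so this change brings no sign of higher toxicity in this test. The true size of the step stays unknown because the reading ends at a limit: the limit of > 61000 nM in this assay, at which 1 of the 4 values shown sits.

These compounds do not separate the loss of the hydroxyl from the arrival of the fluorine. Going by these compounds, how an aminophenyl or a carboxyphenyl group would read at this place also stays open.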